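Replacing the pyridin-2-yl group of compound 3

This account rests on a few compounds, and the source may have more. Where it says the series, first, only, none or still open, it means among the compounds named here.

For the measured compounds named here, in a functional assay on ECa-109 cells for antiproliferative activity against ECa-109 cell line (Homo sapiens), read by MTT assay, with a stated time of 72 h (on this read-out lower numbers stand for stronger inhibition and higher numbers for weaker inhibition), compound 3 `O=C(N/N=C/c1ccccn1)c1cccc(S(=O)(=O)N2CCOCC2)c1` gives 55700 nM and stands highest, making it the weakest of the three measured so far. Compound 1 `C/C(=N\NC(=O)c1cccc(S(=O)(=O)N2CCOCC2)c1)c1cc(Br)ccc1O` at 5280 nM and compound 2 `C/C(=N\NC(=O)c1cccc(S(=O)(=O)N2CCOCC2)c1)c1cc(F)ccc1O` at 3270 nM both sit lower. Compound 4 `O=C(N/N=C/c1cc(Br)cc(Br)c1O)c1cccc(S(=O)(=O)N2CCOCC2)c1` differs from compound 3 in one place 3,5-dibromo-2-hydroxyphenyl in place of pyridin-2-yl on a carbon with a double bond to nitrogen and is still unmeasured. Going by the values given here, no measured step tests this change directly. The only one, a 1.6-fold lower number from compound 1 to compound 2 (0.21 log units; within the scatter), puts fluoro in place of bromo and stays within the scatter. Compound 1 at 5280 nM and compound 2 at 3270 nM also carry a hydroxyphenyl group with a halogen, so a clear drop is expected. The estimated step is a 12-fold lower number from compound 3 to compound 4 (1.09 log units; beyond the scatter) and lies beyond the scatter. The estimate for compound 4 is 4500 nM (range 1300 nM to 16000 nM).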

Compound 4, half-maximal inhibitory concentration: 10300 nM
Estimate against measurement, compound 4: 2.3-fold (0.36 log units) below; the range from low to high includes it.
By their numbers in this assay, from the lowest: compounds 2, 1 and 4 (each within the scatter of the next, the first and the last beyond it); then compound 3.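

In this assay the swap to 3,5-dibromo-2-hydroxyphenyl on a carbon with a double bond to nitrogen gives a 5.4-fold lower number from compound 3 to compound 4 (0.73 log units; beyond the scatter) and shows that the group at this place can shift the number. It is the first change of this group among the compounds shown, and the first one-place step to pass beyond the scatter. Nothing measured here explains the step.

From the compounds shown here alone, the hydroxy group and the two bromines enter together, so their separate shares remain unknown. Going by these compounds, how an unsubstituted phenyl or an aminophenyl group would behave at this place also stays open.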